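Urea swap in a series at the assay limit

A few compounds are considered here, and "the series" means these few. Any claim that something is new, unique, unknown or untested is made for them only; others in the source may bear on it.

Measured in a functional assay on HL-60 cells (Homo sapiens) for inhibition, read by CCK-8 assay, with a stated time of 48 h; a higher number here means a weaker inhibitor, a lower number a stronger inhibitor (both values are limits):
Compound 1 `COc1ccc(NC(=O)NCCNS(=O)(=O)c2ccc(-c3ccccc3OCc3ccccc3)s2)cc1` gives > 50000 nM (limit)
Compound 2 `O=[N+]([O-])c1cccc(NC(=S)NCCNS(=O)(=O)c2ccc(-c3ccccc3OCc3ccccc3)s2)c1` gives > 50000 nM (limit)

Compound 2 stands at > 50000 nM in this assay and this is a limit, not a number. Among the measured compounds shown here, the only measured step is a step that the two limits leave unreadable from compound 1 to compound 2 and it gives no size to carry forward. For the measured compounds named here, the series so far shows the limit of > 50000 nM in this assay, at which 2 of the 2 values shown sit, and nothing more.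

Compound 3 `O=C(NCCNS(=O)(=O)c1ccc(-c2ccccc2OCc2ccccc2)s1)Nc1cc(Cl)cc(Cl)c1` follows from compound 2 through a group of 11 heavy atoms (7 carbon, 1 nitrogen, 1 oxygen, 2 chlorine; one six-membered aromatic ring of carbon only) in place of a group of 12 heavy atoms (7 carbon, 2 nitrogen, 2 oxygen, 1 sulfur; one six-membered aromatic ring of carbon only), on an amine nitrogen and so carries (3,5-dichlorophenyl)carbamoyl on an amine nitrogen. Going by the values given here, no measured step bears on this change with a readable size, so any expectation in this assay is loose. A modest move toward stronger inhibition is expected, and another limit remains quite possible. The estimated step is an at least 2.0-fold lower number from compound 2 to compound 3 (0.30 log units; that floor lies within the scatter) and it carries wide uncertainty. Compound 3 is expected at 25000 nM, with an estimated range of 4000 nM to 50000 nM in this series.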

Compound 3, half-maximal inhibitory concentration: 11700 nM
Beside the measured number, compound 3's estimate is 2.1-fold (0.33 log units) above it; low and high end bracket the measured number.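

With the carbonyl kept, 3,5-dichlorophenyl in place of 4-methoxyphenyl on an amide-type nitrogen gives an at least 4.2-fold lower number from compound 1 to compound 3 (0.63 log units; beyond the scatter) in this assay, the first readable move at this position, while the step between compound 1 and compound 2 cannot be read. The wider exchange, (3,5-dichlorophenyl)carbamoyl in place of the sulfur-bearing group of compound 2 on an amine nitrogen, gives an at least 4.2-fold lower number from compound 2 to compound 3 (0.63 log units; beyond the scatter), but it changes more than one part of the group and so cannot assign the shift to any single part. Both steps start from a limit, so their sizes are floors, and most of the series still rests there: the limit of > 50000 nM in this assay, at which 2 of the 3 values shown sit.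

Open is how much of the shift needs both chlorines, since a single chlorine or a trifluoromethyl group on the phenyl ring does not appear among the compounds shown. Also open, on these data alone, is whether the same aryl group would behave alike with a thiocarbonyl in place of the carbonyl, or with a longer chain in place of the saturated chain on the amine nitrogen.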